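The source may hold more compounds than are shown below. What is called first, only, known or untested is meant among the compounds shown, and "the series" means these compounds.

Measured so far in a functional assay on MCF-10A cells (Homo sapiens) for antiproliferative activity, with a stated time of 48 h; on this read-out higher numbers stand for an effect only at larger amounts of compound and lower numbers for an effect already at smaller amounts:
- compound 1 `COc1ccc2nc(C)cc(NCc3cccnc3)c2c1` gives 49300 nM
- compound 2 `COc1ccc2nc(C)cc(NCc3cccc(F)c3)c2c1` gives 14700 nM
- compound 3 `COc1ccc2nc(C)cc(NCc3ccc(OC)c(F)c3)c2c1` gives 10300 nM

Compound 2 shares the low end of these numbers with its nearest neighbour (a 1.4-fold lower number from compound 2 to compound 3 (0.15 log units; within the scatter)). The one clear gap is on the other side (a 3.4-fold lower number from compound 1 to compound 2 (0.53 log units; beyond the scatter)).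

Compound 4 `COc1ccc2nc(C)cc(NCc3cccc(CO)c3)c2c1` has hydroxymethyl in place of fluoro on an aromatic carbon, meta to a large group (hydroxymethyl in place of fluoro on an aromatic carbon). Among the measured compounds shown here, no measured step makes this exchange, so the evidence is indirect. For the measured compounds named here, two steps touch the same aromatic ring: the swap of the whole ring (a 3.4-fold lower number from compound 1 to compound 2 (0.53 log units; beyond the scatter)) was modest, and the added methoxy (a 1.4-fold lower number from compound 2 to compound 3 (0.15 log units; within the scatter)) did not leave the scatter. Neither suggests a large step on a single substituent, so only a small rise in the number is expected, and that direction is tentative.

The expected step is small (a 1.4-fold higher number from compound 2 to compound 4 (0.13 log units; within the scatter)).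

In this assay the estimate for compound 4 is 20000 nM, expected to fall in the range (7000 nM to 50000 nM).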

Compound 4, half-maximal effective concentration: 24700 nM
The estimate for compound 4 lay 1.2-fold (0.09 log units) below the measured number, and the stated range covers the measured number.
By their numbers in this assay, from the lowest: compounds 3, 2, 4 and 1 (each within the scatter of the next, the first and the last beyond it).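

In this assay, the exchange of fluoro for hydroxymethyl on an aromatic carbon, meta to a large group, gives a 1.7-fold higher number from compound 2 to compound 4 (0.23 log units; within the scatter) and so stays within the scatter. This is the only step shown that replaces the substituent at this place, and it shows that hydroxymethyl, with 1 hydrogen-bond donor and 1 hydrogen-bond acceptor, can stand where fluoro stood, with neither, without a difference beyond the scatter. Nothing at hand gives a reason for this result.

As far as these compounds go, whether an amine, a carboxylic acid or a longer chain at this place would give a step beyond the scatter remains open. Also open, from the compounds shown here alone, is how hydroxymethyl would read with the methoxy of compound 3 on the same ring.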